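A few compounds are considered here, and "the series" means these few. Any claim that something is new, unique, unknown or untested is made for them only; others in the source may bear on it.

Three compounds share one core and differ only in the group carried on the five-membered aromatic ring with three nitrogen atoms. Compound 1 `O=C1O[C@H]([C@@H](O)Cn2cc(CNS(=O)(=O)c3ccc(Cl)cc3F)nn2)C(OCc2ccccc2)=C1OCc1ccccc1` gives 20700 nM in a functional assay on HeLa cells (Homo sapiens) for antiproliferative activity, read by MTT assay, with a stated time of 72 h (a lower number here means a stronger inhibitor, a higher number a weaker inhibitor), compound 2 `C[Si](C)(C)c1cn(C[C@H](O)[C@H]2OC(=O)C(OCc3ccccc3)=C2OCc2ccccc2)nn1` gives 22300 nM, and compound 3 `COc1ccc(-c2cn(C[C@H](O)[C@H]3OC(=O)C(OCc4ccccc4)=C3OCc3ccccc3)nn2)cc1` gives 16400 nM. Compound 3 stands no further from either neighbour than the usual scatter: the three numbers lie together, and nothing separates them beyond repeat variation. Among the measured compounds shown here, the one counted step, a 1.4-fold lower number from compound 2 to compound 3 (0.13 log units; within the scatter), also stayed within the scatter.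

Compound 4 `O=C1O[C@H]([C@@H](O)Cn2cc(CCO)nn2)C(OCc2ccccc2)=C1OCc1ccccc1` is reached from compound 3 by 2-hydroxyethyl in place of 4-methoxyphenyl on an aromatic carbon. The step from compound 2 to compound 3 at the same carbon bears on it and was within the scatter; compound 1, carrying yet another group there, likewise sits within the scatter of compound 3. On that basis no step beyond the scatter is expected in this assay, and the expected step is a 1.1-fold higher number from compound 3 to compound 4 (0.04 log units; within the scatter). Compound 4 is therefore estimated at 18000 nM, with a range from 8000 nM to 40000 nM.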

Compound 4, half-maximal inhibitory concentration: 68800 nM
Compound 4: the middle estimate sits 3.8-fold (0.58 log units) below what was measured; measured number outside the range, above it.
By their numbers in this assay, from the lowest: compounds 3, 1 and 2 (each within the scatter of the next); then compound 4.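

Among the compounds shown here, at this aromatic carbon, the earlier groups had left the numbers within the scatter, but in this assay 2-hydroxyethyl gives the first steps beyond it: a 4.2-fold higher number from compound 3 to compound 4 (0.62 log units; beyond the scatter), a 3.1-fold higher number from compound 2 to compound 4 (0.49 log units; beyond the scatter) and a 3.3-fold higher number from compound 1 to compound 4 (0.52 log units; beyond the scatter). The position is therefore not indifferent to its group, although the loss of a ring alone does not account for the change, since the group on compound 2 also has no ring and that compound stays within the scatter of compound 3. Nothing available here explains why this group behaves differently from the other three.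

The compounds shown leave open whether the step follows from the hydroxyl or from the short chain itself. A plain ethyl group, a longer chain ending in hydroxyl or an amine in place of that hydroxyl would bear on this.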